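The source may hold more compounds than are shown below. What is called first, only, known or untested is meant among the compounds shown, and "the series" means these compounds.

Measured compounds:
compound 1 `COc1ccc(NCN2C(=O)c3ccccc3C2=O)cc1` — 97.2%
compound 2 `CCN(CC)c1ccc(NCN2C(=O)c3ccccc3C2=O)c(C)c1` — 81%
compound 3 `COc1ccc(N(C)CN2C(=O)c3ccccc3C2=O)cc1` — 87%

In an assay on isolated protein for inhibition of ribosomal protein S6 kinase alpha-2 (Homo sapiens), read by fluorescence, with a stated time of 20 min, tested at 10 uM (on this read-out lower numbers stand for less inhibition and higher numbers for more inhibition at the one concentration tested (going by the name of the read-out)), compound 3 stands second highest of the three numbers; compound 2 lies within the scatter of it, while compound 1 lies above it by a step beyond the scatter. Compound 4 `COc1ccc(N(CN2C(=O)c3ccccc3C2=O)C(C)=O)cc1` differs from compound 3 by acetyl in place of methyl on a nitrogen on an aromatic ring. Within the data shown here, the one measured step at the same nitrogen, a number 10.2 percentage points lower from compound 1 to compound 3 (beyond the scatter), came with methyl in place of hydrogen and was modest. Acetyl in place of methyl at that nitrogen is a larger change of the same kind, so a further modest lowering in this assay is expected, though with wide uncertainty. Compound 4 is therefore estimated at 70% (range 40% to 92%), a step of a number 17 percentage points lower from compound 3 to compound 4 (beyond the scatter) expected.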

Compound 4, a percentage reported as inhibition, at one concentration (the size of the read-out at that concentration, not a potency): 17.2%
Estimate against measurement, compound 4: 52.8 percentage points above, outside the stated range (below it).
By their numbers in this assay, from the lowest: compound 4; then compounds 2 and 3 (each within the scatter of the next); then compound 1.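

In this assay, the nitrogen on the aromatic ring separates methyl sharply from acetyl: a number 69.8 percentage points lower from compound 3 to compound 4 (beyond the scatter), against only a number 10.2 percentage points lower from compound 1 to compound 3 (beyond the scatter) for methyl in place of hydrogen. Acetyl in place of hydrogen gives a number 80 percentage points lower from compound 1 to compound 4 (beyond the scatter), so the read-out at this position depends heavily on which group is attached, not merely on whether the hydrogen is replaced. No available evidence bears on the reason for this large step.

As far as these compounds go, whether the loss goes with the carbonyl or with the added carbons of acetyl remains open. Ethyl or a longer alkyl chain on this nitrogen would separate the two.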